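The source may report more compounds than this note shows. Statements on the series, on what has been measured and on what is new or still open speak of the compounds shown alone.

Going by the values given here, compound 1, `O=C(c1ncc(-c2ccccn2)o1)[C@H]1COc2cc(Oc3ccccc3)ccc2C1`, is one of three compounds measured in an assay for inhibition of Fatty-acid amide hydrolase 1 (Rattus norvegicus), using a Dixon plot (on this read-out higher numbers stand for weaker inhibition and lower numbers for stronger inhibition), where compound 1 gives 18 nM. Compound 2, `O=C(c1ncc(-c2ccccn2)o1)[C@H]1COc2cc(OCc3ccccc3)ccc2C1`, gives 18 nM in this assay, and compound 3, `O=C(c1ncc(-c2ccccn2)o1)[C@@H]1COc2cc(Oc3ccccc3)ccc2C1`, gives 27 nM. Compound 1 thus sits level with compound 2 at the digits shown, the two together at the low end of the three numbers, and its largest gap is to compound 3. The step from compound 1 to compound 2, no change at the digits printed from compound 1 to compound 2 (within the scatter), and the step from compound 1 to compound 3, a 1.5-fold higher number from compound 1 to compound 3 (0.18 log units; within the scatter), both stay within the scatter; the latter rests on (the fact that compounds 1 and 3 differ only in the configuration as drawn).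

Compound 4, `O=C(c1ncc(I)o1)[C@H]1COc2cc(Oc3ccccc3)ccc2C1`, is not yet measured. Its change from compound 1 is iodo in place of pyridin-2-yl on an aromatic carbon. Neither measured step touches the five-membered aromatic ring, so nothing measured bears directly on this change; the two known steps were small, but both concern other parts of the molecule. A step in this assay beyond the scatter is therefore possible in either direction, and the expectation is correspondingly wide. Compound 4 is expected to give 60 nM, in the range 10 nM to 400 nM, which is an estimated step of a 3.3-fold higher number from compound 1 to compound 4 (0.52 log units; beyond the scatter).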

Compound 4, inhibition constant: 20 nM
Compound 4: middle estimate off by 3.0-fold (0.48 log units), on the high side; the measured number falls inside the stated range.
By their numbers in this assay, from the lowest: compounds 1, 2, 4 and 3 (each within the scatter of the next).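

Going by these compounds alone, compound 4 gives the first reading at this position, because compounds 1, 2 and 3 all carry pyridin-2-yl there and differ only elsewhere. In this assay, replacing that whole six-membered aromatic ring, on the aromatic carbon next to the ring oxygen, with a single iodine atom leaves the number within the scatter (a 1.1-fold higher number from compound 1 to compound 4 (0.05 log units; within the scatter)). The pyridin-2-yl ring, with its 6 heavy atoms and 1 hydrogen-bond acceptor, is therefore not required at this position to keep the read-out at the level of compound 1, at least when iodo takes its place, and nothing available explains why the two groups read alike.

The compounds shown leave open whether the same holds for other groups on this carbon, such as an amine, a carboxylic acid or a plain phenyl ring, or for a bare hydrogen, so one substitution cannot yet say how broad this freedom is. They also leave open how iodo reads when it is combined with the benzyl group of compound 2 or the opposite configuration of compound 3.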